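The source may report more compounds than this note shows. Statements on the series, on what has been measured and on what is new or still open speak of the compounds shown alone.

Compound 1 `CCCn1c(-c2ccc(O)cc2)c(C)c2ccccc21` is tested in a functional assay on HeLa cells (Homo sapiens) for inhibition, read by trypan blue exclusion, with a stated time of 72 h; a lower number here means a stronger inhibitor of growth, a higher number a weaker inhibitor of growth; there compound 1 gives > 20000 nM, which is a limit of the assay and not a number. Compound 2 `CCCn1c(-c2ccc(O)c(O)c2)c(C)c2cc(O)ccc21` gives in this assay > 20000 nM, again a limit rather than a number. Compound 3 `Cc1c(-c2ccc(O)c(O)c2)n(CCCCOc2ccccc2)c2ccc(O)cc12` gives 10000 nM in this assay. The change from compound 2 to compound 3 is phenoxymethyl in place of hydrogen on a saturated chain carbon, three bonds along the chain from an aromatic nitrogen and it made an at least 2.0-fold lower number from compound 2 to compound 3 (0.30 log units; that floor lies within the scatter), a step that rests on (the limit of > 20000 nM in this assay, at which 2 of the 3 values shown sit). The difference between the cores of compound 1 and compound 2 is not broken down here. Compound 4 `Cc1c(-c2ccc(O)cc2)n(CCCCOc2ccccc2)c2ccccc12` carries the same change against compound 1: phenoxymethyl in place of hydrogen on a saturated chain carbon, three bonds along the chain from an aromatic nitrogen. Since that change made an at least 2.0-fold lower number from compound 2 to compound 3 (0.30 log units; that floor lies within the scatter), a step sitting at the scatter floor, compound 4 is expected to move by an at least 1.3-fold lower number from compound 1 to compound 4 (0.12 log units; that floor lies within the scatter) in this assay. Compound 4 is therefore estimated at 15000 nM, between 6000 nM and 40000 nM.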

Compound 4, concentration for 50% growth inhibition: 11000 nM
The estimate for compound 4 lay 1.4-fold (0.13 log units) above the measured number, and the stated range covers the measured number.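

In this assay, phenoxymethyl in place of hydrogen on the core of compound 1 gave an at least 1.8-fold lower number from compound 1 to compound 4 (0.25 log units; that floor lies within the scatter), and the comparison with the earlier core reads: the same change on two cores in this assay, an at least 2.0-fold lower number (0.30 log units; that floor lies within the scatter) from compound 2 to compound 3 and an at least 1.8-fold lower number (0.25 log units; that floor lies within the scatter) from compound 1 to compound 4; the limit leaves it open whether they differ. On both cores the change leads from a limit of the assay to a measured number, so the direction is the same in these two pairs, but each step is only a floor that lies within the scatter. The true size of neither step is known, and how well the change carries over between the cores stays unsettled: the limit of > 20000 nM in this assay, at which 2 of the 4 values shown sit.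

The compounds shown leave open whether the phenoxymethyl group itself matters. A plain butyl chain, a longer chain, an amine or a carboxylic acid in its place could each give a different answer.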